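Nitrofuran carboxamides: tert-butyl to chlorophenoxymethyl on Vero cells

The source may report more compounds than this note shows. Statements on the series, on what has been measured and on what is new or still open speak of the compounds shown alone.

Three nitrofuran carboxamides have been run in an ADME assay on Vero cells (Chlorocebus sabaeus) for cytotoxicity, read by MTT assay, with a stated time of 48 h; on this read-out lower numbers stand for higher toxicity in this test and higher numbers for lower toxicity in this test. Compound 1 `O=C(Nc1cc2ccccc2o1)c1ccc([N+](=O)[O-])o1` carries a fused bicyclic amine on the amide and in this assay compound 1 gives 40000 nM. Compound 2 `O=C(Nc1ccc2ccccc2c1)c1ccc([N+](=O)[O-])o1` reaches only the limit of the assay, and compound 2 is reported as > 150000 nM. Compound 3 `CC(C)(C)c1ccc(C(C)(C)NC(=O)c2ccc([N+](=O)[O-])o2)cc1`, with the tert-butyl-substituted benzylic amine, also sits at the limit, and compound 3 gives > 150000 nM. Thus compound 3 stands where the numbers run out: the limit of > 150000 nM in this assay, at which 2 of the 3 values shown sit, so nothing separates compound 3 from compound 2 on this read-out, and only compound 1 shows an actual value.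

Compound 4 `CC(C)(NC(=O)c1ccc([N+](=O)[O-])o1)c1ccc(COc2ccccc2Cl)cc1` differs from compound 3 by (2-chlorophenoxy)methyl in place of tert-butyl on an aromatic carbon. The change enters at the place given: on an aromatic carbon of a six-membered aromatic ring of carbon only. Within the data shown here, no measured step tells how such a replacement moves this assay, and no evidence ties any property of the entering group to the read-out.

The expectation for compound 4 is a modest move toward lower numbers, with the step from compound 3 to compound 4 estimated as an at least 2.1-fold lower number from compound 3 to compound 4 (0.33 log units; beyond the scatter). Compound 4 is expected to give 70000 nM in this assay, between 20000 nM and 150000 nM, with a fair chance that only a limit is again reported.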

Compound 4, half-maximal cytotoxic concentration: 30000 nM
The estimate for compound 4 lay 2.3-fold (0.37 log units) above the measured number, and the stated range covers the measured number.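

Among these compounds, the replacement of tert-butyl by (2-chlorophenoxy)methyl on an aromatic carbon, para to a large group, is the first change that can be read at this position, and in this assay it gives an at least 5.0-fold lower number from compound 3 to compound 4 (0.69 log units; beyond the scatter) with the rest of the structure unchanged. The read-out therefore responds to what sits at this place, and among the two compounds that share this amine side a measured value now stands, with compound 4 at 30000 nM on the same test. The step is bounded on one side only, and its true size stays unknown while compound 3 is reported as a limit and not a number: the limit of > 150000 nM in this assay, at which 2 of the 4 values shown sit.

With a single change at a single position, the compounds shown do not separate the contributions of the entering group's ring, its ether oxygen and its chlorine, and no property of that group is tied to the read-out. A phenoxymethyl group without the chlorine, a methoxymethyl group or a carboxylic acid at the same place would show which part of the entering group carries the move.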